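The source may report more compounds than this note shows. Statements on the series, on what has been measured and on what is new or still open speak of the compounds shown alone.

In a functional assay on MCF7 cells (Homo sapiens) for inhibition, read by sulforhodamine B assay (a higher number here means a weaker inhibitor of growth, a lower number a stronger inhibitor of growth), three compounds that share one core have been measured. Compound 1 (`c1ccc(-c2ccc(-c3ccc(-c4nc5ccccc5[nH]4)cc3)cc2)cc1`) gives 39200 nM, compound 2 (`Fc1ccc(-c2ccc(-c3ccc(-c4nc5ccccc5[nH]4)cc3)cc2)cc1`) gives 36200 nM, and compound 3 (`FC(F)(F)c1ccc(-c2ccc(-c3ccc(-c4nc5ccccc5[nH]4)cc3)cc2)cc1`) gives 41400 nM. Compound 3 therefore stands level with the other two, within the scatter of both.

The next compound, compound 4 (`FC(F)(F)Oc1ccc(-c2ccc(-c3ccc(-c4nc5ccccc5[nH]4)cc3)cc2)cc1`), carries trifluoromethoxy in place of trifluoromethyl on an aromatic carbon, para to a large group: trifluoromethoxy in place of trifluoromethyl on an aromatic carbon. Within the data shown here, no measured step makes this exact exchange, but the measured steps do change the group at this same place. Replacing hydrogen gave small steps with both groups tried: a 1.1-fold lower number from compound 1 to compound 2 (0.03 log units; within the scatter) and a 1.1-fold higher number from compound 1 to compound 3 (0.02 log units; within the scatter). Among the measured compounds shown here, the closest precedent exchanges one fluorinated group for another, and it was equally small: a 1.1-fold higher number from compound 2 to compound 3 (0.06 log units; within the scatter).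

On this evidence, no step beyond the scatter is expected in this assay, and the estimated step is a 1.0-fold lower number from compound 3 to compound 4 (0.01 log units; within the scatter). For compound 4, the expected value is about 40000 nM, with an estimated range of 25000 nM to 65000 nM.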

Compound 4, concentration for 50% growth inhibition: 38400 nM
Compound 4: middle estimate off by 1.0-fold (0.02 log units), on the high side; the measured number falls inside the stated range.
By their numbers in this assay, from the lowest: compounds 2, 4, 1 and 3 (each within the scatter of the next).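

In this assay, trifluoromethoxy adds an oxygen and a hydrogen-bond acceptor at this place on the aromatic ring, yet the reading holds steady against all three earlier compounds: a 1.1-fold lower number from compound 3 to compound 4 (0.03 log units; within the scatter), a 1.1-fold higher number from compound 2 to compound 4 (0.03 log units; within the scatter) and a 1.0-fold lower number from compound 1 to compound 4 (0.01 log units; within the scatter). The four groups seen here, hydrogen, fluoro, trifluoromethyl and trifluoromethoxy, therefore all give numbers within the scatter of one another, and the added acceptor brings no measurable change. Nothing available explains why this position stays so flat.

As far as these compounds go, it remains open whether an amine, a carboxylic acid or a longer chain such as butyl at this place would move the number beyond the scatter. From the compounds shown here alone, these four compounds differ only at this one place, so the effect of changes elsewhere on the shared core also remains open.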